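Compound 4 and a Series Resting at a Limit

The source may report more compounds than this note shows. Statements on the series, on what has been measured and on what is new or still open speak of the compounds shown alone.

In a physicochemical assay for permeability, using PAMPA (on this read-out higher numbers stand for higher permeability and lower numbers for lower permeability), compound 1 `COc1cc2oc(=O)n(CCC(=O)O)c2cc1Cl` gives < 3 nm/s, which is a limit of the assay and not a number. Compound 2 `C[C@@H](Oc1cc2oc(=O)n(CCC(=O)O)c2cc1Cl)c1ncco1` gives < 3 nm/s, again a limit. Compound 3 `Cc1ccnc([C@@H](C)Oc2cc3oc(=O)n(CCC(=O)O)c3cc2Cl)c1` gives < 3 nm/s, also a limit, so its true value is not known. The whole series stands at one place: the limit of < 3 nm/s in this assay, at which 3 of the 3 values shown sit.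

Compound 4 `C[C@@H](Oc1cc2oc(=O)n(CCC(=O)O)c2cc1Cl)c1ncccn1` has not yet been measured. It differs from compound 3 in one place: pyrimidin-2-yl in place of 4-methylpyridin-2-yl on a saturated chain carbon bound to an oxygen on an aromatic ring and a saturated chain carbon.

For the measured compounds named here, two measured steps bear on this change, both at the same kind of position or close to it: a step that the two limits leave unreadable from compound 1 to compound 2 and a step that the two limits leave unreadable from compound 2 to compound 3. Both run between limits, so neither has a readable size. Neither step gives any sign of movement in this assay, so no shift beyond the usual scatter is expected, and the estimated step is a step that the limit leaves unreadable from compound 3 to compound 4. For compound 4 the expected value is 2 nm/s, with an estimated range from 1 nm/s to 3 nm/s, and the assay will most likely report a limit again.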

Compound 4, apparent permeability: < 3 nm/s
Compound 4 ended at the assay's limit (the forecaster's own chance of this, stated with the estimate: 90%); the middle value does not contradict the limit.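

Compound 4 also gives a limit and not a number, so its steps from compound 1, compound 2 and compound 3 cannot be read in this assay. The series stays at one place: the limit of < 3 nm/s in this assay, at which 4 of the 4 values shown sit.

The compounds shown leave open how permeable any of them truly is, and whether any of these changes moves the read-out at all.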